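Swapping a Pyrazole for a Thiophene on a Sulfonamide

A few compounds are considered here, and "the series" means these few. Any claim that something is new, unique, unknown or untested is made for them only; others in the source may bear on it.

Of the compounds shown here, two that share one core have been tested in a functional assay on NCI-H1975 cells (Homo sapiens) for cytotoxicity, read by MTT assay, with a stated time of 48 h; on this read-out lower numbers stand for stronger inhibition and higher numbers for weaker inhibition. Compound 1, `COc1cc2c(Oc3ccc(NC(=O)c4c(C)n(C)n(-c5ccccc5)c4=O)cc3F)ccnc2cc1OCCCN1CCN(C)CC1`, gives 1060 nM. Compound 2, `COc1cc2c(Oc3ccc(NS(=O)(=O)c4cccc(-c5cnn(C)c5)c4)cc3F)ccnc2cc1OCCCN1CCN(C)CC1`, gives 6120 nM, the higher of the two numbers and so the weaker of the pair, with compound 1 as its nearest neighbour at a gap beyond the usual scatter. Compound 3, `COc1cc2c(Oc3ccc(NS(=O)(=O)c4cccc(-c5ccsc5)c4)cc3F)ccnc2cc1OCCCN1CCN(C)CC1`, has not yet been measured. It differs from compound 2 in one place: thiophen-3-yl in place of 1-methyl-1H-pyrazol-4-yl on an aromatic carbon. Within the data shown here, no measured pair shows this exact exchange, so the expectation rests on the change itself, which replaces one five-membered aromatic ring with another five-membered aromatic ring. The step from compound 2 to compound 3 is therefore expected to be small, a 1.2-fold lower number from compound 2 to compound 3 (0.09 log units; within the scatter), and not beyond the scatter in either direction. Compound 3 is estimated at 5000 nM, with a range from 1800 nM to 14000 nM.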

Compound 3, half-maximal inhibitory concentration: 2300 nM
For compound 3 the middle estimate is 2.2-fold (0.34 log units) above the measured one; the measured number falls inside the stated range.
By their numbers in this assay, from the lowest: compound 1; then compound 3; then compound 2.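

At this place, on an aromatic carbon of a six-membered aromatic ring of carbon only and meta to a large group, this assay shows a 2.7-fold lower number from compound 2 to compound 3 (0.43 log units; beyond the scatter) when thiophen-3-yl enters in place of 1-methyl-1H-pyrazol-4-yl. One five-membered aromatic ring therefore cannot simply be assumed to stand in for another at this place, even though neither carries a hydrogen-bond donor or a net charge. No measurement at hand explains the step.

This single exchange alters the ring's hetero atoms and removes the methyl group together, so it cannot separate their contributions. It also leaves open how a furan-3-yl ring, a pyridin-3-yl ring or a simple amine would compare at this place.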